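From an imidazole to a pyrrolidinylmethyl on the shared core

This account rests on a few compounds, and the source may have more. Where it says the series, first, only, none or still open, it means among the compounds named here.

Compound 2 `COc1ccc(Sc2ccc(-c3ncc[nH]3)cc2)cc1` is known in an assay (Rattus norvegicus) for binding affinity to prostacyclin receptor (Homo sapiens), read by radioligand binding (a higher number here means a weaker inhibitor, a lower number a stronger inhibitor), only through a limit: compound 2 gives < 10000 nM, which is a bound of the measurement and not a number, as the limit of < 10000 nM in this assay, at which 1 of the 2 values shown sits, records. Compound 1 `CC/N=C(\N)Nc1ccc(Sc2ccc(OC)cc2)cc1` carries an acyclic group on the same aromatic carbon, and in this assay compound 1 gives 251 nM. The step that the limit leaves unreadable from compound 1 to compound 2 therefore has no readable size. Compound 3 `COc1ccc(Sc2ccc(CN3CCCC3)cc2)cc1` differs from compound 2 by (pyrrolidin-1-yl)methyl in place of 1H-imidazol-2-yl on an aromatic carbon. Among the compounds with values here, no measured step bears directly on this change, and the only step available, a step that the limit leaves unreadable from compound 1 to compound 2, cannot be read because of the limit of < 10000 nM in this assay, at which 1 of the 2 values shown sits. The direction in this assay is thus open. Because compound 1 gives 251 nM with a different group on the same aromatic carbon, compound 3 is expected at 1200 nM, with a range from 150 nM to 8000 nM. The expected step that the limit leaves unreadable from compound 2 to compound 3 is estimated against a limit and so is not itself readable.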

Compound 3, inhibition constant: 10000 nM
Beside the measured number, compound 3's estimate is 8.3-fold (0.92 log units) below it; the whole stated range lies below it.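

With compound 3, this position gains its first readable step among fully measured compounds: in this assay there is a 40-fold higher number from compound 1 to compound 3 (1.60 log units; beyond the scatter), and there is also a number no lower from compound 2 to compound 3 (the limit leaves the size open). The shared core therefore does not hold the value of compound 1 once (pyrrolidin-1-yl)methyl stands on this aromatic carbon in place of the acyclic group, so the group at this position clearly counts. The steps involving compound 2 cannot be read, because compound 2 is known only through a limit: the limit of < 10000 nM in this assay, at which 1 of the 3 values shown sits.

Going by these compounds, whether compound 3 truly differs from compound 2 therefore stays open, as does whether the ring or the carbon link of (pyrrolidin-1-yl)methyl accounts for the large step from the acyclic group. The compounds shown also leave open how an open-chain dimethylaminomethyl group, a primary amine or a carboxylic acid on this aromatic carbon would read in this assay.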